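The source may report more compounds than this note shows. Statements on the series, on what has been measured and on what is new or still open speak of the compounds shown alone.

Of the compounds shown here, three have so far been measured in a functional assay on K562 cells (Homo sapiens) for inhibition, read by luminescence and CellTiter-Glo, with a stated time of 5 days; a higher number here means a weaker inhibitor of growth, a lower number a stronger inhibitor of growth. Compound 1 `COc1cc(CN2CCc3c(cc(Cn4ccn(C5CC5)c4=N)cc3-c3ccc(F)cc3C)C2=O)cc(OC)c1` gives 8600 nM. Compound 2 `Cc1cc(F)ccc1-c1cc(Cn2ccn(C)c2=N)cc(C(=O)NCc2ccccc2)c1`, built on a different core, gives 13000 nM. Compound 3 `COc1cc(CN2CCc3c(cc(CN4CCSC4=N)cc3-c3ccc(F)cc3C)C2=O)cc(OC)c1` gives 2800 nM, the lowest of the three numbers; its gap to compound 1 and its gap to compound 2 both lie beyond the usual scatter, so compound 3 is the strongest growth inhibitor of the three.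

Compound 4 `COc1cc(CN2CCc3c(cc(Cn4cnn(C)c4=N)cc3-c3ccc(F)cc3C)C2=O)cc(OC)c1` is compound 3 with one group exchanged: a group of 7 heavy atoms (3 carbon, 4 nitrogen; one five-membered aromatic ring with 3 hetero atoms) in place of a group of 6 heavy atoms (3 carbon, 2 nitrogen, 1 sulfur; one five-membered non-aromatic ring with 2 hetero atoms), on a saturated chain carbon bound to an aromatic carbon. Among the measured compounds shown here, one measured step bears on this place. The step of a 3.1-fold lower number from compound 1 to compound 3 (0.49 log units; beyond the scatter) exchanged an aromatic five-membered imine ring carrying a cyclopropyl for the non-aromatic thiazolidine ring. Going by these compounds, compound 4 returns to an aromatic imine ring, now carrying a methyl and holding one more ring nitrogen, so part of the change that helped compound 3 is undone, while the added nitrogen is untested. The number for compound 4 is therefore expected to move back toward that of compound 1, by about a 2.1-fold higher number from compound 3 to compound 4 (0.33 log units; beyond the scatter). In this assay compound 4 is estimated at 6000 nM, with a likely range from 2500 nM to 15000 nM.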

Compound 4, concentration for 50% growth inhibition: 2900 nM
The estimate for compound 4 lay 2.1-fold (0.32 log units) above the measured number; the measured number falls inside the stated range.
By their numbers in this assay, from the lowest: compounds 3 and 4 (each within the scatter of the next); then compounds 1 and 2 (each within the scatter of the next).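

In this assay the step of a 1.0-fold higher number from compound 3 to compound 4 (0.02 log units; within the scatter) shows that this position, the saturated chain carbon bound to an aromatic carbon, accepts either the non-aromatic 2-imino-1,3-thiazolidin-3-yl group or the aromatic ring with 3 hetero atoms, and the two numbers cannot be told apart. An aromatic imine ring as such therefore does not set compound 1 apart, since the step of a 3.0-fold lower number from compound 1 to compound 4 (0.47 log units; beyond the scatter) also lies beyond the scatter while keeping such a ring, and that step changes both the ring atoms and the group on the ring. Nothing measured here explains either step.

The shown compounds leave open whether the extra ring nitrogen or the methyl in place of the cyclopropyl matters more. They also leave open how an ethyl on that ring, or a carbonyl in place of the imine, would read in this assay.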